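Demethylation of the aryl methyl ether at a fixed cytotoxicity level

The source may hold more compounds than are shown below. What is called first, only, known or untested is meant among the compounds shown, and "the series" means these compounds.

Measured in a functional assay on KM12 cells (Homo sapiens) for cytotoxicity, read by sulforhodamine B assay, with a stated time of 48 h, tested at 1 uM; a higher number here means a weaker effect of the compound at the concentration tested, a lower number a stronger effect:
compound 1, `Cc1cc(O)cc(-c2nn(CC#N)cc2-c2ccnc(-c3ccc(Oc4ccccc4)cc3)c2)c1`: -39%
compound 2, `COc1cc(C)cc(-c2nn(CC#N)cc2-c2ccnc(-c3ccc(N(C)C)cc3)c2)c1`: -37%

Compound 2 stands highest of the two numbers in this assay, but compound 1 lies only slightly lower and within the scatter, so the two read as one level. Compound 3, `Cc1cc(O)cc(-c2nn(CC#N)cc2-c2ccnc(-c3ccc(N(C)C)cc3)c2)c1`, differs from compound 2 by hydrogen in place of methyl on an oxygen on an aromatic ring. The hydroxy of compound 3 is already present in compound 1, which gives -39% in this assay. Going by the values given here, no measured step covers this change, so the expected step of a number 1 percentage points lower from compound 2 to compound 3 (within the scatter) is none beyond the scatter. Compound 3 is therefore estimated at -38%, with a range from -52% to -24%.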

Compound 3, a percentage reported as activity, at one concentration (the size of the read-out at that concentration, not a potency): -9%
Compound 3: middle estimate off by 29 percentage points, on the low side, outside the stated range (above it).
By their numbers in this assay, from the lowest: compounds 1 and 2 (each within the scatter of the next); then compound 3.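

In this assay, methoxy to hydroxy on the 3-methoxy-5-methylphenyl group is not a silent change: it brings a number 28 percentage points higher from compound 2 to compound 3 (beyond the scatter), a weaker effect at the concentration tested. With the hydroxy held fixed, dimethylamino in place of phenoxy brings a number 30 percentage points higher from compound 1 to compound 3 (beyond the scatter), so the hydroxy alone does not set the level, and its reading depends on the other group present. Nothing in the data shown accounts for either step. Going by these compounds, how phenoxy reads alongside methoxy stays open, as does how an amine or a longer ether such as ethoxy would read in place of the hydroxy.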